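Sulfonyl substituent swap from compound 3 to compound 4

The source may report more compounds than this note shows. Statements on the series, on what has been measured and on what is new or still open speak of the compounds shown alone.

Three compounds share one core and differ only in the group on the sulfonyl sulfur. In a functional assay (Platelet, plasma) for inhibition, with Homo sapiens as the target (on this read-out lower numbers stand for stronger inhibition and higher numbers for weaker inhibition), compound 1 `N#Cc1cc2c(nc1N1CCC(C(=O)NS(=O)(=O)Cc3ccccc3F)CC1)COC2=O`, carrying 2-fluorobenzyl, gives 23700 nM. Compound 2 `CC(c1ccccc1)S(=O)(=O)NC(=O)C1CCN(c2nc3c(cc2C#N)C(=O)OC3)CC1`, carrying 1-phenylethyl, gives 4160 nM. Compound 3 `N#Cc1cc2c(nc1N1CCC(C(=O)NS(=O)(=O)c3ccc(Cl)s3)CC1)COC2=O`, carrying 5-chlorothiophen-2-yl, gives 4470 nM, which is level with compound 2 and well under compound 1.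

The next change leads to compound 4 `N#Cc1cc2c(nc1N1CCC(C(=O)NS(=O)(=O)C3(c4ccccc4)CC3)CC1)COC2=O`, with 1-phenylcyclopropyl in place of 5-chlorothiophen-2-yl on a sulfonyl sulfur.

All three measured steps sit at this same place. Leaving 2-fluorobenzyl gives a 5.7-fold lower number from compound 1 to compound 2 (0.76 log units; beyond the scatter) and a 5.3-fold lower number from compound 1 to compound 3 (0.72 log units; beyond the scatter), both modest and beyond the scatter. The remaining swap gives a 1.1-fold higher number from compound 2 to compound 3 (0.03 log units; within the scatter), within the scatter. The entering group reads closest to the 1-phenylethyl of compound 2, at 4160 nM, so that value is the best guide. Within the data shown here, no measured compound has a three-membered ring at this place, which keeps the range wide. No step beyond the scatter is expected in this assay, and no firm direction either, the estimate being a 1.1-fold lower number from compound 3 to compound 4 (0.05 log units; within the scatter). Compound 4 is expected at 4000 nM, with an estimated range of 1500 nM to 11000 nM.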

Compound 4, half-maximal inhibitory concentration: 4100 nM
For compound 4 the middle estimate is 1.0-fold (0.01 log units) below the measured one; low and high end bracket the measured number.
By their numbers in this assay, from the lowest: compounds 4, 2 and 3 (each within the scatter of the next); then compound 1.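

In this assay the step to 1-phenylcyclopropyl brings a three-membered ring to this place on the sulfonyl sulfur, yet a 1.1-fold lower number from compound 3 to compound 4 (0.04 log units; within the scatter) and a 1.0-fold lower number from compound 2 to compound 4 (0.01 log units; within the scatter) both stay within the scatter, so neither this ring nor the exchange of the 5-chlorothiophen-2-yl ring for an all-carbon group with more heavy atoms separates these compounds. Compound 1 remains the only one apart, and a 5.8-fold lower number from compound 1 to compound 4 (0.76 log units; beyond the scatter) is a modest step beyond the scatter that matches its earlier steps to compound 2 and compound 3, leaving compounds 2, 3 and 4 on one level despite their different groups. Nothing at hand accounts for this shared level or for the gap to compound 1.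

The compounds shown leave open whether a group of another kind on the sulfonyl sulfur, such as an amine or a straight alkyl chain, would move the read-out away from this level. They also leave open whether the weaker number of compound 1 goes with its fluorine or with the benzyl itself, a question that an unsubstituted benzyl group would address.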